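The source may hold more compounds than are shown below. What is called first, only, known or untested is meant among the compounds shown, and "the series" means these compounds.

The two measured compounds:
compound 1 `N#CC1(NC(=O)[C@@H](CC(=O)N2CCOCC2)CC2CCCCC2)CC1` with 135 nM
compound 2 `N#C[C@@]1(NC(=O)[C@@H](CC(=O)N2CCOCC2)CC2CCC(c3ccccc3)CC2)CCN(C2CCCCC2)C1` with 3140 nM

Both were tested in an assay on isolated protein for inhibition of cathepsin S (Homo sapiens); a lower number here means a stronger inhibitor, a higher number a weaker inhibitor. Of the two numbers, compound 2 has the higher one, and its gap to compound 1 lies beyond the usual scatter, so compound 1 is the stronger inhibitor of the pair. The two structures differ in several places at once, so no single change can be held responsible for that gap.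

Compound 3 `CC1CCC(C[C@H](CC(=O)N2CCOCC2)C(=O)N[C@]2(C#N)CCN(C3CCCCC3)C2)CC1` has not yet been measured. It differs from compound 2 in one place only: methyl in place of phenyl on a saturated ring carbon. Compound 1 carries a plain cyclohexyl at that position and gives 135 nM, yet it also differs from compound 2 elsewhere, so that number cannot be credited to the ring substituent alone.

Trimming the phenyl to a methyl brings compound 3 nearer to compound 1 at that position, so the step of a 1.7-fold lower number from compound 2 to compound 3 (0.24 log units; within the scatter) is expected to run toward a lower number, modest in size and possibly still within the scatter. Compound 3 is estimated at 1800 nM, with a range from 500 nM to 6500 nM.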

Compound 3, half-maximal inhibitory concentration: 14 nM
Estimate against measurement, compound 3: 130-fold (2.11 log units) above, and the stated range ends above it.
By their numbers in this assay, from the lowest: compound 3; then compound 1; then compound 2.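

Swapping 4-phenylcyclohexyl for 4-methylcyclohexyl gives a 220-fold lower number from compound 2 to compound 3 (2.35 log units; beyond the scatter) in this assay, a large step for a change made at a single place. Until now, no difference in this series could be tied to one change, but this pair shows that the group on this saturated ring carbon can, by itself, move the number far beyond the scatter. All other parts of the structure are the same in both compounds, so those shared parts do not prevent a low number, as compound 3 gives 14 nM while carrying them.

No supporting measurement explains why this change has such a large effect. From the compounds shown here alone, the pair offers only methyl and phenyl at this ring carbon, so it remains open how an ethyl, a longer chain, a methoxy group or an amine would read there, and whether the number climbs gradually as the group grows or jumps only once the group reaches a certain size.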